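A few compounds are considered here, and "the series" means these few. Any claim that something is new, unique, unknown or untested is made for them only; others in the source may bear on it.

Compound 1 `COc1ccc(Cn2c(C(=O)N3CCC(C(N)=O)CC3)cc3sccc32)cc1` is the parent of the pair. In an ADME assay on HEK-293T cells (Homo sapiens) for cytotoxicity, read by luminescence, with a stated time of 24 h (a higher number here means that more compound is tolerated, a lower number that less compound is tolerated), compound 1 gives > 100000 nM, which is a limit of the assay rather than a number. Compound 2 `COc1ccc(Cn2c(C(=O)N3CCC(C(=O)NC(C)c4ccccc4)CC3)cc3sccc32)cc1` carries 1-phenylethyl in place of hydrogen on the amide-type nitrogen. In this assay compound 2 gives > 100000 nM, again a limit of the assay, so compound 2 stands where compound 1 stands. The step that the two limits leave unreadable from compound 1 to compound 2 cannot be read, because both values sit at the limit of > 100000 nM in this assay, at which 2 of the 2 values shown sit. Compound 3 `CCCNC(=O)C1CCN(C(=O)c2cc3sccc3n2Cc2ccc(OC)cc2)CC1` differs from compound 2 by propyl in place of 1-phenylethyl on an amide-type nitrogen. Going by the values given here, no measured step bears on this change with a readable size. Compound 3 is therefore expected to sit at the limit as well, estimated at 100000 nM within 50000 nM to 300000 nM. The step of a number no higher from compound 2 to compound 3 (the limit leaves the size open) is expected to be none beyond the scatter.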

Compound 3, half-maximal cytotoxic concentration: 18800 nM
Estimate against measurement, compound 3: 5.3-fold (0.73 log units) above, and the stated range ends above it.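

In this assay, the group on this amide-type nitrogen proves able to shift the result, which the earlier pair could not show: propyl in place of 1-phenylethyl gives an at least 5.3-fold lower number from compound 2 to compound 3 (0.72 log units; beyond the scatter), and propyl in place of hydrogen gives an at least 5.3-fold lower number from compound 1 to compound 3 (0.72 log units; beyond the scatter). Propyl alone yields a readable value here, so the change does not run in step with the size of the group, as both the smaller hydrogen and the larger 1-phenylethyl stay at the limit. The full size of both steps stays open because compound 1 and compound 2 each give only a limit: the limit of > 100000 nM in this assay, at which 2 of the 3 values shown sit.

On these data alone, whether a longer chain such as butyl would lower the number further remains open. So does the effect of an amine at the end of the propyl chain.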